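A few compounds are considered here, and "the series" means these few. Any claim that something is new, unique, unknown or untested is made for them only; others in the source may bear on it.

Among the compounds with values here, in a functional assay on CCRF-CEM cells (Homo sapiens) for antiproliferative activity (a lower number here means that less compound is tolerated, a higher number that more compound is tolerated), compound 1 `Cc1cn(C2OC(CO[Si](C)(C)C(C)(C)C)C3(OS(=O)(=O)C=C3N)C2O[Si](C)(C)C(C)(C)C)c(=O)n(CCCNC(=O)[C@@H]2CCCN2C(=O)[C@@H](N)C(C)C)c1=O` gives 10000 nM, the lowest of the two numbers measured so far. Its close relative, compound 2 `Cc1cn(C2OC(CO[Si](C)(C)C(C)(C)C)C3(OS(=O)(=O)C=C3N)C2O[Si](C)(C)C(C)(C)C)c(=O)n(CCCNC(=O)[C@@H]2CCCN2C(=O)[C@@H](N)CCC(=O)O)c1=O`, gives 30000 nM. Within the data shown here, that comparison is the only measured step, and it swaps isopropyl for 2-carboxyethyl on a saturated chain carbon bound to an amine nitrogen and a carbonyl carbon. Compound 3 `Cc1cn(C2OC(CO[Si](C)(C)C(C)(C)C)C3(OS(=O)(=O)C=C3N)C2O[Si](C)(C)C(C)(C)C)c(=O)n(CCCNC(=O)[C@@H](N)C(C)C)c1=O` has not been measured and carries a different change: 1-amino-2-methylpropyl in place of 1-((1-amino-2-methylpropyl)carbonyl)pyrrolidin-2-yl on a carbonyl carbon, with 1-amino-2-methylpropyl in place of 1-((1-amino-2-methylpropyl)carbonyl)pyrrolidin-2-yl on a carbonyl carbon. Among the measured compounds shown here, no measured pair shows this change, so the modest 3.0-fold higher number from compound 1 to compound 2 (0.48 log units; beyond the scatter) serves only as a rough guide to size. A similarly modest move to a higher number is expected, though the direction is uncertain. The estimated step is a 1.5-fold higher number from compound 1 to compound 3 (0.18 log units; within the scatter). For compound 3 the expected value is 15000 nM, with an estimated range from 5000 nM to 50000 nM.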

Compound 3, half-maximal cytotoxic concentration: 9600 nM
Estimate against measurement, compound 3: 1.6-fold (0.19 log units) above; the measured number falls inside the stated range.
By their numbers in this assay, from the lowest: compounds 3 and 1 (each within the scatter of the next); then compound 2.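

In this assay, replacing 1-((1-amino-2-methylpropyl)carbonyl)pyrrolidin-2-yl with 1-amino-2-methylpropyl on the carbonyl carbon gives a 1.0-fold lower number from compound 1 to compound 3 (0.02 log units; within the scatter), so this step cannot be told apart from repeat-measurement noise. The group on that carbon can therefore go from 12 heavy atoms with a five-membered ring to 5 heavy atoms with no ring without a readable shift in this number, something the earlier side-chain swap between compound 1 and compound 2 could not show. No supporting evidence is available to explain this result.

The compounds shown leave open whether the amine on this group is needed, since a plain methyl or ethyl on the carbonyl carbon does not appear among them. Also open, as far as these compounds go, is whether 2-carboxyethyl would raise the number on the shorter chain of compound 3 as it does on the longer chain of compound 1.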